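Ester at the Oxygen of Compound 2: Expected Inhibition

The compounds below may be only part of what the source reports. "The series", "measured", "known", "first", "only" and "open" are said of these compounds alone.

Of the compounds shown here, two sharing one core have been measured in a functional assay on the whole organism (stomach) for inhibition, with Canis familiaris (Canis lupus familiaris) as the target, at a dose of 5 mg/kg by the intravenous route; on this read-out lower numbers stand for a weaker effect and higher numbers for a stronger effect at the one dose given. Compound 1 `Cc1nc2c(OCc3ccccc3)cccn2c1C#N` gives 4% in this assay, and compound 2 `CCOCc1c(C)nc2c(OCc3ccccc3)cccn12` gives 35%. Within the data shown here, the single step between them, a number 31 percentage points higher from compound 1 to compound 2 (beyond the scatter), lies beyond the scatter; compound 2 stands highest of the two numbers, with compound 1 the nearest and lower. Compound 3 `Cc1nc2c(OCc3ccccc3)cccn2c1COC(=O)c1cccnc1` has not yet been measured. It differs from compound 2 in one place: (pyridin-3-yl)carbonyl in place of ethyl on an oxygen on a saturated carbon. Among the measured compounds shown here, no measured step touches this oxygen; the only measured step swapped ethoxymethyl for cyano on an aromatic carbon and gives no direct guidance for the change to compound 3. Lacking such guidance, compound 3 is expected to remain near compound 2, with an estimated step of no change at the digits printed from compound 2 to compound 3 (within the scatter). Compound 3 is estimated at 35%, within a range from 10% to 65%.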

Compound 3, a percentage reported as inhibition, in the whole organism at one dose (the size of the read-out at that dose, not a potency): 88%
Compound 3: middle estimate off by 53 percentage points, on the low side, outside the stated range (above it).
By their numbers in this assay, from the lowest: compound 1; then compound 2; then compound 3.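

In this assay, among these compounds, the oxygen on a saturated carbon turns out to be highly sensitive to the group it carries: (pyridin-3-yl)carbonyl in place of ethyl gives a number 53 percentage points higher from compound 2 to compound 3 (beyond the scatter), a rise the earlier compounds gave no sign of at this oxygen. The entering group brings both a six-membered aromatic ring with a hetero atom and a carbonyl, neither of which the ethyl has, and this single step cannot separate what each part contributes. No measurement is at hand that would explain the rise.

The compounds shown leave open whether acetyl, which keeps the carbonyl without the ring, or benzoyl, which has a ring without its nitrogen, would reach the level of compound 3 . They also leave open how a pyridin-3-ylmethyl group, which keeps the ring without the carbonyl, would read at this oxygen.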